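Removing the butyl group from compound 3

This account rests on a few compounds, and the source may have more. Where it says the series, first, only, none or still open, it means among the compounds named here.

Among the compounds with values here, in a functional assay on M21 cells (Homo sapiens) for antiproliferative activity, read by sulforhodamine B assay, with a stated time of 48 h (on this read-out higher numbers stand for weaker inhibition and lower numbers for stronger inhibition), compound 3 (`CCCCc1ccc(NS(=O)(=O)c2ccc(N3CCNC3=O)cc2)cc1`) gives 450 nM, the highest of the three numbers so far. Compound 1 (`CCc1ccccc1NS(=O)(=O)c1ccc(N2CCNC2=O)cc1`) gives 180 nM and compound 2 (`O=C1NCCN1c1ccc(S(=O)(=O)Nc2ccc3[nH]ccc3c2)cc1`) gives 87 nM, both lower beyond the scatter. Compound 4 (`O=C1NCCN1c1ccc(S(=O)(=O)Nc2ccccc2)cc1`) has hydrogen in place of butyl on an aromatic carbon, para to a large group: hydrogen in place of butyl on an aromatic carbon. Within the data shown here, no two measured compounds differ in one place only, so the series offers no direct guide to this change and the expectation stays loose. In this assay the expected change is small, within the scatter, with a slight lean toward a higher number: a 1.3-fold higher number from compound 3 to compound 4 (0.12 log units; within the scatter). For compound 4 the estimate is 600 nM, with an expected range of 150 nM to 2500 nM.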

Compound 4, half-maximal inhibitory concentration: 200 nM
Estimate against measurement, compound 4: 3.0-fold (0.48 log units) above, and the stated range covers the measured number.
By their numbers in this assay, from the lowest: compound 2; then compounds 1 and 4 (each within the scatter of the next); then compound 3.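

In this assay, hydrogen in place of butyl on the aromatic carbon para to a large group gives a modest step beyond the scatter, a 2.3-fold lower number from compound 3 to compound 4 (0.35 log units; beyond the scatter), so butyl at this place carries a measurable penalty. Hydrogen in place of ethyl on an aromatic carbon gives no such separation, a 1.1-fold higher number from compound 1 to compound 4 (0.05 log units; within the scatter), which stays within the scatter. Nothing measured here explains either step.

Open, from the compounds shown here alone, is whether the number climbs steadily with chain length or only with butyl. Also open, going by these compounds, is how an amine or a carboxylic acid on this carbon would compare with hydrogen.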